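The source may hold more compounds than are shown below. What is called first, only, known or untested is meant among the compounds shown, and "the series" means these compounds.

Among the compounds with values here, the series shares one core, and only two members of it have been measured. Compound 1 `NC(=O)c1ccc2c(c1)CCOC2CCN1CC=C(c2c[nH]c3c(Cl)c(Cl)ccc23)CC1` opens the set. In an assay on cells for binding affinity to 5-hydroxytryptamine receptor 1B (Homo sapiens), read by radioligand binding (a lower number here means a stronger inhibitor, a higher number a weaker inhibitor), compound 1 gives > 1000 nM, which is a limit of the assay rather than a number. Compound 2 `NC(=O)c1ccc2c(c1)CCOC2CCN1CC=C(c2c[nH]c3ccc(F)cc23)CC1` is the second measured member. In this assay compound 2 gives > 1000 nM, again a limit and not a number. Where compound 2 stands is therefore only this: both values recorded so far sit at the limit of > 1000 nM in this assay, at which 2 of the 2 values shown sit, so no number places compound 2 relative to compound 1.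

Compound 3 `NC(=O)c1ccc2c(c1)CCOC2CCN1CC=C(c2[nH]nc3cc(F)ccc23)CC1` differs from compound 2 in one place: 6-fluoro-2H-indazol-3-yl in place of 5-fluoro-1H-indol-3-yl on a double-bonded ring carbon. Within the data shown here, no step between two measured compounds exists here, so the size of such a change in this assay cannot be read from any pair. Because both measured values sit at the limit of > 1000 nM in this assay, at which 2 of the 2 values shown sit, the expected step that the limit leaves unreadable from compound 2 to compound 3 is taken as none beyond the usual scatter. Compound 3 is accordingly expected to give 1500 nM, with a range from 300 nM to 6000 nM, and a limit rather than a number is the more likely outcome.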

Compound 3, inhibition constant: 210 nM
Beside the measured number, compound 3's estimate is 7.1-fold (0.85 log units) above it; measured number below the stated range.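

Setting 6-fluoro-2H-indazol-3-yl in place of 5-fluoro-1H-indol-3-yl on the double-bonded ring carbon is the first change here to yield a number rather than a limit in this assay, and it gives an at least 4.7-fold lower number from compound 2 to compound 3 (0.67 log units; beyond the scatter). The earlier compounds shown here, compound 1 and compound 2, differ in the group at this place, yet neither gave a number, so they could not show that the group held here can move the read-out clear of the limit. Compound 2 stands at a limit and not a number, so the full size of this step cannot be read, because the measured values offer no number at that end of it: the limit of > 1000 nM in this assay, at which 2 of the 3 values shown sit.

Still open is which part of the change carries the step, the second nitrogen of the five-membered aromatic ring or the place of the fluorine, and the compounds shown change both together. Also open, as far as these compounds go, is how the read-out would respond to a chlorine or a methoxy group in place of that fluorine on the 2H-indazol-3-yl group.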